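This account rests on a few compounds, and the source may have more. Where it says the series, first, only, none or still open, it means among the compounds named here.

In a physicochemical assay for solubility, at pH 7.4 (a higher number here means a more soluble compound, a lower number a less soluble compound), compound 1 `CCc1ccc(NC(=O)Nc2cc(C)nc3ccccc23)cc1` gives 3300 nM. Within the data shown here, this is the higher of the two numbers available so far. Compound 2 `Cc1cc(NC(=O)Nc2ccc(F)c(F)c2)c2ccccc2n1` gives 500 nM, and the gap between the two lies beyond the usual scatter of repeat measurements.

Compound 3 `COC(=O)c1ccc(NC(=O)Nc2cc(C)nc3ccccc23)cc1` has not yet been measured. It has methoxycarbonyl in place of ethyl on an aromatic carbon, para to a large group: methoxycarbonyl in place of ethyl on an aromatic carbon. Among the measured compounds shown here, no two measured compounds differ in just one place, so no measured step can guide this change. The expectation in this assay is therefore a modest drop, only a little beyond the scatter, and it remains uncertain. The estimated change is a 2.5-fold lower number from compound 1 to compound 3 (0.40 log units; beyond the scatter). For compound 3, the expected value is 1300 nM, with an estimated range of 300 nM to 5000 nM.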

Compound 3, solubility: 1200 nM
Compound 3: middle estimate off by 1.1-fold (0.03 log units), on the high side, within the range that was stated.
By their numbers in this assay, from the lowest: compound 2; then compound 3; then compound 1.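

In this assay, putting methoxycarbonyl in place of ethyl on an aromatic carbon, para to a large group, gives a 2.8-fold lower number from compound 1 to compound 3 (0.44 log units; beyond the scatter). Among these compounds, this is the first comparison in which only one place changes, so it shows that the group at this position affects the reading, with a modest step that still lies beyond the usual scatter. It also shows that exchanging ethyl, which has no hydrogen-bond acceptors, for a group that has them does not raise the number in this pair, though nothing available explains the drop.

The compounds shown leave open which way a carboxylic acid, an amine or a longer chain at this position would move the number. They also leave open whether the same exchange would give a similar step with a different group elsewhere on the molecule.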